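From 5-(hydroxycarbamoyl)pentyl to 4-(hydroxycarbamoyl)benzyl

This account rests on a few compounds, and the source may have more. Where it says the series, first, only, none or still open, it means among the compounds named here.

In a functional assay on HCT-116 cells (Homo sapiens) for inhibition, read by MTT assay, with a stated time of 72 h (on this read-out lower numbers stand for stronger inhibition and higher numbers for weaker inhibition), compound 1 `O=C(CCCCCCCN(Cc1ccc(F)cc1)c1ncc(C(=O)NCCCn2ccnc2)s1)NO` gives 63000 nM and compound 2 `O=C(CCCCCN(Cc1ccc(F)cc1)c1ncc(C(=O)NCCCn2ccnc2)s1)NO` gives 19000 nM as the lower of the two numbers. Compound 3 `O=C(NO)c1ccc(CN(Cc2ccc(F)cc2)c2ncc(C(=O)NCCCn3ccnc3)s2)cc1` differs from compound 2 by 4-(hydroxycarbamoyl)phenyl in place of 4-(hydroxycarbamoyl)butyl on a saturated chain carbon bound to a nitrogen on an aromatic ring at the same place. Within the data shown here, the only measured step is a 3.3-fold lower number from compound 1 to compound 2 (0.52 log units; beyond the scatter) and it changes chain length alone. Among the measured compounds shown here, no measured step covers an aromatic ring here, so a modest move to a lower number is expected with wide uncertainty. Compound 3 is estimated at 10000 nM (range 2500 nM to 40000 nM) in this assay for now. The estimate means a 1.9-fold lower number from compound 2 to compound 3 (0.28 log units; within the scatter) as the expected step.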

Compound 3, half-maximal inhibitory concentration: 99000 nM
Compound 3: middle estimate off by 9.9-fold (1.00 log units), on the low side; the whole stated range lies below it.
By their numbers in this assay, from the lowest: compound 2; then compounds 1 and 3 (each within the scatter of the next).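

The step of a 5.2-fold higher number from compound 2 to compound 3 (0.72 log units; beyond the scatter) in this assay shows that 4-(hydroxycarbamoyl)phenyl at this place does not hold the lower number reached with 4-(hydroxycarbamoyl)butyl. The step of a 1.6-fold higher number from compound 1 to compound 3 (0.20 log units; within the scatter) puts this aromatic group level with the longer 6-(hydroxycarbamoyl)hexyl chain, so a phenyl linker and a long chain cannot be told apart here. No measurement on hand explains the result.

Still open, as far as these compounds go, is whether a shorter chain such as 3-(hydroxycarbamoyl)propyl lowers the number further, and how a carboxylic acid in place of the hydroxycarbamoyl group reads.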